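The compounds below may be only part of what the source reports. "The series", "measured", "known", "first", "only" and "open" are said of these compounds alone.

Of the compounds shown here, three have so far been measured in a functional assay on Flp-In T-REx293 cells for antagonist activity at Free fatty acid receptor 1 (Homo sapiens), read by calcium flux; on this read-out higher numbers stand for weaker inhibition and lower numbers for stronger inhibition. Compound 1 `O=S(=O)(Nc1ccc(Oc2ccccc2)cc1)c1ccc(F)cc1` gives 12900 nM and compound 2 `Cc1ccc(S(=O)(=O)Nc2ccc(Oc3ccccc3)cc2)cc1` gives 10000 nM; the two differ at a single aromatic carbon, and the step of a 1.3-fold lower number from compound 1 to compound 2 (0.11 log units; within the scatter) stays within the scatter, so nothing can be read from it beyond the fact that the two numbers sit together. Compound 3 `Cc1ccccc1Oc1cc(F)cc(N2Cc3ccccc3S2(=O)=O)c1` is built on a different core and gives 44700 nM, the highest number of the three, separated from compound 1 and from compound 2 by margins beyond the scatter, so among these three it is the weakest inhibitor.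

Compound 4 `O=S1(=O)c2ccccc2CN1c1cc(F)cc(Oc2ccccn2)c1` has not yet been measured. It differs from compound 3 in one place: pyridin-2-yl in place of 2-methylphenyl on an oxygen on an aromatic ring. Going by the values given here, no measured step touches a change of this kind; the single step in hand concerns a methyl and a fluoro on another core and was itself within the scatter. The expectation therefore rests on the starting point alone, and the expected step of a 1.1-fold lower number from compound 3 to compound 4 (0.05 log units; within the scatter) is none beyond the scatter. Compound 4 is accordingly estimated at 40000 nM, with a range from 15000 nM to 100000 nM.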

Compound 4, half-maximal inhibitory concentration: > 100000 nM
Compound 4 gave a limit, no number; the forecaster's own chance of this, stated with the estimate: 25%; middle value at least 2.5-fold (0.39 log units) away from the limit.
By their numbers in this assay, from the lowest: compounds 2 and 1 (each within the scatter of the next); then compound 3. At a limit, above all of these: compound 4.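

Swapping 2-methylphenyl for pyridin-2-yl on the oxygen is the first change shown at this position, and in this assay it weakens inhibition, with an at least 2.2-fold higher number from compound 3 to compound 4 (0.34 log units; beyond the scatter). Going by these compounds alone, the one earlier step, a 1.3-fold lower number from compound 1 to compound 2 (0.11 log units; within the scatter), touched another place on another core and showed no change beyond the scatter, whereas this position responds to the group it carries. The reading for compound 4 is a limit of the assay and not a number, so the step gives only a lower bound on the loss, and its full size cannot be read: the limit of > 100000 nM in this assay, at which 1 of the 4 values shown sits.

The exchange removes the methyl and brings in a ring nitrogen with one hydrogen-bond acceptor at the same time, so the compounds shown do not tell which of these two differences goes with the loss. They also leave open how this position would respond to a pyridin-3-yl group or to a phenyl ring carrying a carboxylic acid or an amine, and whether any group on this oxygen would give a lower number than compound 3 does.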